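The compounds below may be only part of what the source reports. "The series", "measured", "known", "first", "only" and "open" are said of these compounds alone.

Measured so far in a functional assay on 3T3-L1 cells (Mus musculus) for inhibition, with a stated time of 20 min, tested at 20 uM; on this read-out higher numbers stand for more inhibition at the one concentration tested (going by the name of the read-out) and lower numbers for less inhibition:
Compound 1 `Cc1ccc(S(=O)(=O)N(Cc2cn(Cc3ccc(F)cc3)nn2)Cc2c(-c3ccccc3)c3ccccc3n2S(=O)(=O)c2ccc(C)cc2)cc1` gives -7.6%.
Compound 2 `Cc1ccc(S(=O)(=O)n2cc(CN(Cc3cn(Cc4ccccc4)nn3)S(=O)(=O)c3ccccc3)c3ccccc32)cc1` gives -18%.
Compound 3 `Cc1ccc(S(=O)(=O)N(Cc2cn(Cc3cccc(F)c3F)nn2)Cc2cn(S(=O)(=O)c3ccc(C)cc3)c3ccccc23)cc1` gives 71.5%.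

Among these three numbers compound 1 stands second highest. Its nearest neighbour is compound 2, whose number lies below it by more than the scatter, while compound 3 lies far above it, also beyond the scatter. Compound 4 `Cc1ccc(S(=O)(=O)N(Cc2cn(Cc3ccccc3)nn2)Cc2c(-c3ccccc3)c3ccccc3n2S(=O)(=O)c2ccc(C)cc2)cc1` is the next compound to be tested in this assay. It differs from compound 1 in one place only: hydrogen in place of fluoro on an aromatic carbon. Going by the values given here, no pair of measured compounds shows the effect of this change, so its step size is unknown from the data. The change removes one fluorine atom and nothing else; a small step is expected, most likely none beyond the scatter, in either direction. Compound 4 is therefore expected to give about -5%, within a range from -25% to 20%. The expected step is a number 2.6 percentage points higher from compound 1 to compound 4 (within the scatter).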

Compound 4, a percentage reported as inhibition, at one concentration (the size of the read-out at that concentration, not a potency): 0.03%
Beside the measured number, compound 4's estimate is 5 percentage points below it; the range from low to high includes it.
By their numbers in this assay, from the lowest: compound 2; then compounds 1 and 4 (each within the scatter of the next); then compound 3.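

In this assay, going by these compounds alone, replacing fluoro with hydrogen on the benzyl ring gives the first direct reading of this position: a number 7.6 percentage points higher from compound 1 to compound 4 (within the scatter). On the core of compound 1, then, this fluorine can go without a change that stands out from the usual scatter of the measurement. Nothing available here explains this result.

On these data alone, it remains open whether a larger group at this place, such as methoxy, an amine or a carboxylic acid, would shift the read-out. The same swap on a different core also remains untested in the compounds shown.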